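The compounds below may be only part of what the source reports. "The series", "measured", "known", "first", "only" and "open" are said of these compounds alone.

Measured so far: compound 1 `CC(=O)OC[C@H]1O[C@@H](n2cc(-c3cn(Cc4ccc(C(C)C)cc4)nn3)c(=O)[nH]c2=O)C[C@@H]1OC(C)=O` gives 96.5%. Compound 2 `CC(=O)OC[C@H]1O[C@@H](n2cc(-c3cc(-c4ccccc4)no3)c(=O)[nH]c2=O)C[C@@H]1OC(C)=O` gives 92.2%. Compound 3 `CC(C)(C)c1ccc(-c2cc(-c3cn([C@H]4C[C@H](O)[C@@H](CO)O4)c(=O)[nH]c3=O)on2)cc1` gives 79.8%.

These numbers come from a functional assay on HCT-15 cells (Homo sapiens) for cytotoxicity, read by sulforhodamine B assay, tested at 10 uM; on this read-out lower numbers stand for less inhibition and higher numbers for more inhibition at the one concentration tested (going by the name of the read-out). On them compound 2 stands second highest of the three: compound 1 lies within the scatter of it, while compound 3 sits a number beyond the scatter below it. Compound 4 `CC(=O)OC[C@H]1O[C@@H](n2cc(-c3cc(-c4ccc(C(C)C)cc4)no3)c(=O)[nH]c2=O)C[C@@H]1OC(C)=O` has not yet been measured. It differs from compound 2 in one place: isopropyl in place of hydrogen on an aromatic carbon. Among the measured compounds shown here, no pair of measured compounds isolates this change, so the expectation rests on compound 2 and its value of 92.2%. The expected step of a number 0.2 percentage points lower from compound 2 to compound 4 (within the scatter) is none beyond the scatter, in no particular direction. Compound 4 is therefore estimated at 92%, with a range from 80% to 98%.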

Compound 4, a percentage reported as inhibition, at one concentration (the size of the read-out at that concentration, not a potency): 80.9%
For compound 4 the middle estimate is 11.1 percentage points above the measured one, within the range that was stated.
By their numbers in this assay, from the lowest: compounds 3 and 4 (each within the scatter of the next); then compounds 2 and 1 (each within the scatter of the next).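

In this assay, among the compounds shown here, changing phenyl to 4-isopropylphenyl gives a step of a number 11.3 percentage points lower from compound 2 to compound 4 (beyond the scatter), the first comparison here in which only one place differs. It shows that this aromatic carbon, para to a large group, is not indifferent to substitution: isopropyl there goes with less inhibition than hydrogen at the one concentration tested. Nothing measured here explains the step. On these data alone, whether a methyl, an amine or a carboxylic acid on the same carbon would give a similar loss remains open. So does whether any such change would alter potency, since a single concentration cannot show that.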